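A Sulfonamide Replaces a Methylsulfanyl Group on the Benzylamide

The compounds below may be only part of what the source reports. "The series", "measured", "known", "first", "only" and "open" are said of these compounds alone.

Three benzamides sharing one core have been measured in an assay on HeLa cells with Bile acid receptor (Homo sapiens) as the target, read by a luciferase reporter, with a stated time of 24 h; on this read-out lower numbers stand for an effect already at smaller amounts and higher numbers for an effect only at larger amounts of compound. Compound 1 `CC(C)(C)c1ccc(C(=O)NCc2ccc(N)cc2Cl)cc1` gives 46 nM, compound 2 `CSc1ccc(CNC(=O)c2ccc(C(C)(C)C)cc2)cc1` gives 100 nM, and compound 3 `CC(C)(C)c1ccc(C(=O)NCc2ccc(C(=O)O)cc2F)cc1` gives 7.8 nM. Compound 2 thus stands highest of the three numbers; compound 1 lies nearest to it and compound 3 furthest, with both gaps beyond the usual scatter. The next compound, compound 4 `CC(C)(C)c1ccc(C(=O)NCc2ccc(NS(C)(=O)=O)cc2)cc1`, differs from compound 2 in one place: methanesulfonamido in place of methylsulfanyl on an aromatic carbon. Going by the values given here, no measured pair isolates this exchange, so any expectation rests on the three values alone. Since compound 1 gives 46 nM and compound 3 gives 7.8 nM, both lower than compound 2, a move toward lower numbers seems plausible. In this assay compound 4 is therefore expected to show a step of a 3.3-fold lower number from compound 2 to compound 4 (0.52 log units; beyond the scatter). The estimate for compound 4 is 30 nM, ranging from 8 nM to 120 nM.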

Compound 4, half-maximal effective concentration: 44 nM
Beside the measured number, compound 4's estimate is 1.5-fold (0.17 log units) below it; the measured number falls inside the stated range.
By their numbers in this assay, from the lowest: compound 3; then compounds 4 and 1 (each within the scatter of the next); then compound 2.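

In this assay, methanesulfonamido in place of methylsulfanyl, on an aromatic carbon para to a large group, brings a 2.3-fold lower number from compound 2 to compound 4 (0.36 log units; beyond the scatter) and is a modest step. This is the only pair shown that differs in one place, and it shows that this position accepts the larger group, which brings a hydrogen-bond donor, without a rise in the number. Nothing at hand accounts for the step.

On these data alone, whether an acetamido group or the longer ethanesulfonamido group at this place would move the number further stays open.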